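The source may report more compounds than this note shows. Statements on the series, on what has been measured and on what is new or still open speak of the compounds shown alone.

Of the compounds shown here, three built on one shared core have been tested in a functional assay on MCF7 cells (Homo sapiens) for cytotoxicity, read by MTT assay, with a stated time of 4 days; a lower number here means a stronger inhibitor, a higher number a weaker inhibitor. Compound 1 `C=C1C[C@]23C[C@@]1(O)CC[C@H]2c1ccc(O)c(C)c1[C@@H]3Cn1cc(-c2ccccn2)nn1` carries a free hydroxy on its aromatic ring, and in this assay compound 1 gives > 20000 nM, which is a limit of the assay rather than a number. Compound 2 `Cc1c(O)ccc2c1[C@H](Cn1cc(-c3ccccc3)nn1)[C@@]13CC(=O)[C@@](C)(CC[C@@H]21)C3` also carries the free hydroxy, and in this assay compound 2 gives > 20000 nM, again only a limit. Compound 3 `C=C1C(=O)[C@]23C[C@@]1(O)CC[C@H]2c1ccc(OS(=O)(=O)c2ccc(C)cc2)c(C)c1[C@@H]3Cn1cc(-c2ccccn2)nn1`, whose aromatic oxygen bears a (4-methylphenyl)sulfonyl group, gives 320 nM in this assay. Compound 2 therefore stands at the limit of > 20000 nM in this assay, at which 2 of the 3 values shown sit, with no number of its own. Among the measured compounds shown here, compound 3 is the only compound with a measured value.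

Compound 4 `Cc1ccc(S(=O)(=O)Oc2ccc3c(c2C)[C@H](Cn2cc(-c4ccccc4)nn2)[C@@]24CC(=O)[C@@](C)(CC[C@@H]32)C4)cc1` has not yet been measured. It differs from compound 2 by (4-methylphenyl)sulfonyl in place of hydrogen on an oxygen on an aromatic ring. For the measured compounds named here, no measured pair differing only in this change exists, so the size of the step must be guessed. Going by the values given here, a gain in potency well beyond the scatter is expected because compound 3, the one compound carrying this same group, gives 320 nM. The expected step is an at least 13-fold lower number from compound 2 to compound 4 (1.12 log units; beyond the scatter). For compound 4 the estimate is 1500 nM, with a range from 300 nM to 8000 nM.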

Compound 4, half-maximal inhibitory concentration: > 20000 nM
Compound 4 ended at the assay's limit (the forecaster's own chance of this, stated with the estimate: 20%); middle value at least 13-fold (1.12 log units) from the limit.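

Compound 2 and compound 4 both sit at a limit of the assay rather than at a number, so no step can be read between them. The compounds shown leave open whether (4-methylphenyl)sulfonyl in place of hydrogen on an oxygen on an aromatic ring changes the value in this assay at all.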